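Amide nitrogen variation: from compound 3 to compound 4

The source may hold more compounds than are shown below. What is called first, only, known or untested is meant among the compounds shown, and "the series" means these compounds.

Three measured compounds share one core and differ only in the group on the amide-type nitrogen. Compound 1 `CCN(CC)S(=O)(=O)c1ccc(S(=O)(=O)N2CCC[C@@H](C(=O)N[C@@H]3CCN(C(=O)OC(C)(C)C)C3)C2)cc1` carries 1-(tert-butoxycarbonyl)pyrrolidin-3-yl there. In a functional assay on MIA PaCa-2 cells (Homo sapiens) for inhibition, read by MTT assay, with a stated time of 3 days (on this read-out higher numbers stand for weaker inhibition and lower numbers for stronger inhibition), compound 1 reaches only the limit > 10000 nM. Compound 2 `CCN(CC)S(=O)(=O)c1ccc(S(=O)(=O)N2CCC[C@@H](C(=O)NC3CN(C(=O)C4CC4)C3)C2)cc1` carries 1-(cyclopropylcarbonyl)azetidin-3-yl, and in this assay compound 2 likewise returns the limit > 10000 nM. Compound 3 `CCN(CC)S(=O)(=O)c1ccc(S(=O)(=O)N2CCC[C@@H](C(=O)NC3COC3)C2)cc1` carries oxetan-3-yl, and in this assay compound 3 also sits at the limit > 10000 nM. Every step among them, a step that the two limits leave unreadable from compound 1 to compound 3, a step that the two limits leave unreadable from compound 2 to compound 3 and a step that the two limits leave unreadable from compound 1 to compound 2, therefore has no readable size, since (the limit of > 10000 nM in this assay, at which 3 of the 3 values shown sit).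

Compound 4 `CCN(CC)S(=O)(=O)c1ccc(S(=O)(=O)N2CCC[C@@H](C(=O)N[C@H]3CCN(C(=O)OC(C)(C)C)C3)C2)cc1` differs from compound 3 by 1-(tert-butoxycarbonyl)pyrrolidin-3-yl in place of oxetan-3-yl on an amide-type nitrogen, the same group as in compound 1 but with the other configuration at its stereocentre. The closest comparison is a step that the two limits leave unreadable from compound 1 to compound 3, which gives no size. With all values at the limit, no shift beyond the scatter can be expected, and compound 4 is expected to remain at the limit. The expected step that the limit leaves unreadable from compound 3 to compound 4 is taken as nil in effect. The estimate for compound 4 is 20000 nM, within 8000 nM to 60000 nM.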

Compound 4, half-maximal inhibitory concentration: > 10000 nM
Compound 4 was reported as a limit; the forecaster's own chance of this, stated with the estimate: 85%; the middle value lies beyond the limit too.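

No new step can be read for compound 4 against compound 1, compound 2 or compound 3, because all four values are limits: the limit of > 10000 nM in this assay, at which 4 of the 4 values shown sit.

The compounds shown leave open whether the group on the amide-type nitrogen, or the configuration separating compound 1 from compound 4, affects this read-out at all.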